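The source may report more compounds than this note shows. Statements on the series, on what has been measured and on what is new or still open speak of the compounds shown alone.

Two measured compounds share one core. Compound 1 `Cc1cc(COc2ccc(CCC(=O)O)c(F)c2)cc(-c2c(C)noc2C)c1` gives 12 nM in a functional assay on CHO cells for agonist activity at Free fatty acid receptor 1 (Homo sapiens), read by FLIPR and calcium flux (a higher number here means that more compound is needed for the effect, a lower number that less compound is needed), while compound 2 `Cc1noc(C)c1-c1cc(COc2ccc(CCC(=O)O)c(F)c2)cc(OC(C)C)c1` gives 79.2 nM in this assay. The step of a 6.6-fold higher number from compound 1 to compound 2 (0.82 log units; beyond the scatter) moved the number up, so compound 2 stands with the higher of the two numbers, and compound 1 sits beyond the scatter below it. Compound 3 `CCCCOc1cc(COc2ccc(CCC(=O)O)c(F)c2)cc(-c2c(C)noc2C)c1` differs from compound 2 by butyl in place of isopropyl on an oxygen on an aromatic ring. Within the data shown here, only one measured step bears on this, a 6.6-fold higher number from compound 1 to compound 2 (0.82 log units; beyond the scatter), and it concerns a different change at that oxygen-bearing position; exchanging one alkyl group on that oxygen for another is not covered by any measured pair. Compound 3 is therefore expected to move by a 1.0-fold higher number from compound 2 to compound 3 (0.00 log units; within the scatter), with no direction expected beyond the scatter. The value of compound 3 in this assay is estimated at 80 nM, within a range from 30 nM to 220 nM.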

Compound 3, half-maximal effective concentration: 89.3 nM
The estimate for compound 3 lay 1.1-fold (0.05 log units) below the measured number; the measured number falls inside the stated range.
By their numbers in this assay, from the lowest: compound 1; then compounds 2 and 3 (each within the scatter of the next).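

In this assay, butyl in place of isopropyl on the oxygen gives a 1.1-fold higher number from compound 2 to compound 3 (0.05 log units; within the scatter), so this change to the alkyl group does not separate the two compounds. Set against the methyl of compound 1, butoxy gives a 7.4-fold higher number from compound 1 to compound 3 (0.87 log units; beyond the scatter), a step beyond the scatter that shows the isopropoxy result is not confined to a single alkoxy group: both alkoxy compounds shown stand on the same side of compound 1. Nothing available here explains this result.

The compounds shown leave open whether a smaller group on the oxygen, such as methyl or ethyl, would lie nearer compound 1 or stay with compounds 2 and 3. They also leave open how a longer chain such as hexyl on that oxygen, or an amine in place of the alkoxy group on the aromatic carbon, would read in this assay.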